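Moving the trifluoromethoxy group on the sulfonyl aryl

The source may hold more compounds than are shown below. What is called first, only, known or untested is meant among the compounds shown, and "the series" means these compounds.

Four compounds share a hydroxy amide framework that carries a sulfonyl aryl on one side and an aryl amide on the other. Compound 1 `CC(O)(CS(=O)(=O)c1ccc(OC(F)(F)F)cc1)C(=O)Nc1ccc(S(F)(F)(F)(F)F)cc1` gives 39300 nM in a functional assay on DU-145 cells (Homo sapiens) for antiproliferative activity, read by propidium iodide staining, with a stated time of 96 h; on this read-out lower numbers stand for stronger inhibition and higher numbers for weaker inhibition. Compound 2 `CC(O)(CS(=O)(=O)c1cccc(OC(F)(F)F)c1)C(=O)Nc1ccc(S(F)(F)(F)(F)F)cc1` carries 3-(trifluoromethoxy)phenyl in place of 4-(trifluoromethoxy)phenyl on a sulfonyl sulfur and gives 26500 nM in this assay; the step is a 1.5-fold lower number from compound 1 to compound 2 (0.17 log units; within the scatter). Compound 3 `CC(O)(CS(=O)(=O)c1ccc(OC(F)(F)F)cc1)C(=O)Nc1cccc(S(F)(F)(F)(F)F)c1` has a core that differs from the core of compound 1, but the difference between the two cores is not broken down here; in this assay compound 3 gives 35600 nM, a value that lies within the usual scatter of the value of compound 1. Compound 4 `CC(O)(CS(=O)(=O)c1cccc(OC(F)(F)F)c1)C(=O)Nc1cccc(S(F)(F)(F)(F)F)c1` has not yet been measured. Its difference from compound 3 is 3-(trifluoromethoxy)phenyl in place of 4-(trifluoromethoxy)phenyl on a sulfonyl sulfur, the same change at the same place as between compound 1 and compound 2. This change occurs twice among these compounds and has been measured once. Because the measured step of a 1.5-fold lower number from compound 1 to compound 2 (0.17 log units; within the scatter) stayed within the scatter, the author expects a step of similar size, a 1.4-fold lower number from compound 3 to compound 4 (0.15 log units; within the scatter), in this assay. Compound 4 is accordingly estimated at 25000 nM, with an expected range from 12000 nM to 55000 nM.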

Compound 4, half-maximal inhibitory concentration: 31500 nM
Estimate against measurement, compound 4: 1.3-fold (0.10 log units) below, and the stated range covers the measured number.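

On the core of compound 3, in this assay, 3-(trifluoromethoxy)phenyl in place of 4-(trifluoromethoxy)phenyl on the sulfonyl sulfur gives a 1.1-fold lower number from compound 3 to compound 4 (0.05 log units; within the scatter). Set side by side, the two steps do not differ: the same change on two cores in this assay, a 1.5-fold lower number (0.17 log units; within the scatter) from compound 1 to compound 2 and a 1.1-fold lower number (0.05 log units; within the scatter) from compound 3 to compound 4, 1.3-fold (0.12 log units) apart, within the scatter of two such steps. This shows that on both cores shown the change stays within the scatter, so the two cores agree in giving no step that can be told from repeat variation; it does not show that the change has a real effect of its own in the same direction on both, and two cores are too few to say how it would behave on others.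

The compounds shown leave open whether a nitrile, an amine or a carboxylic acid in place of the trifluoromethoxy group on the sulfonyl aryl would give a step beyond the scatter. They also leave open whether the same change would stay as small on a core whose aryl amide carries a nitrile or a longer chain.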